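Diaryl urea acrylamides: amide variation at the assay limit

The source may hold more compounds than are shown below. What is called first, only, known or untested is meant among the compounds shown, and "the series" means these compounds.

Compound 1 `CC(NC(=O)/C=C/Oc1ccc(NC(=O)Nc2cc(C(F)(F)F)ccc2Cl)cc1)c1ccccc1`, compound 2 `CNC(=O)/C(C)=C/c1ccc(NC(=O)Nc2ccc(Cl)c(C(F)(F)F)c2)cc1` and compound 3 `C/C(=C\c1ccc(NC(=O)Nc2ccc(Cl)c(C(F)(F)F)c2)cc1)C(=O)N1CC(C)OC(C)C1` share the same core and differ in the amide portion. In a functional assay on HT-29 cells (Homo sapiens) for inhibition, read by MTT assay, with a stated time of 120 h (on this read-out higher numbers stand for weaker inhibition and lower numbers for stronger inhibition), compound 1 gives only a limit of the assay, > 50000 nM. In this assay compound 2 likewise gives a limit, > 50000 nM. Compound 3 also gives a limit in this assay, > 50000 nM. For the measured compounds named here, compound 2 therefore stands at the limit, as do the other two (the limit of > 50000 nM in this assay, at which 3 of the 3 values shown sit), and the single one-place step, a step that the two limits leave unreadable from compound 2 to compound 3, cannot be read. Compound 4 `O=C(/C=C/c1ccc(NC(=O)Nc2ccc(Cl)c(C(F)(F)F)c2)cc1)NC1CCC1` differs from compound 2 by 2-(cyclobutylcarbamoyl)ethenyl in place of 2-(methylcarbamoyl)prop-1-en-1-yl on an aromatic carbon. Going by the values given here, no measured step bears readably on this change. Compound 2 sits at a limit in this assay. Compound 4 is therefore expected to stay at or near that limit, with the estimated step that the limit leaves unreadable from compound 2 to compound 4 uncertain in either direction. The estimated value for compound 4 is 60000 nM, within 15000 nM to 300000 nM.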

Compound 4, half-maximal inhibitory concentration: 4430 nM
For compound 4 the middle estimate is 14-fold (1.13 log units) above the measured one; measured number outside the range, below it.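

In this assay, for the compounds shown here, the change on this aromatic carbon, para to a large group, gives an at least 11-fold lower number from compound 2 to compound 4 (1.05 log units; beyond the scatter) and brings the series off the assay limit for the first time. Going by these compounds alone, the earlier compounds gave only limits, so this is the first readable step. A 2-(cyclobutylcarbamoyl)ethenyl group at this position is therefore compatible with a measurable read-out on the shared core.

The step changes the amide substituent and removes the chain methyl together, so neither can be credited separately. Open too, as far as these compounds go, is how a cyclohexyl ring or an amine-bearing chain on the amide nitrogen would read.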